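A few compounds are considered here, and "the series" means these few. Any claim that something is new, unique, unknown or untested is made for them only; others in the source may bear on it.

Compound 1 `COc1ccc(C(=O)/C=C/c2cc(-c3cc(OC)c(OC)c(OC)c3)n3nc(-c4ccccc4)cc3n2)cc1` gives 13200 nM in a functional assay on MDA-MB-231 cells (Homo sapiens) for antiproliferative activity, read by MTT assay, with a stated time of 24 h; a lower number here means a stronger inhibitor, a higher number a weaker inhibitor.
Compound 2 `COc1cc(-c2cc(/C=C/C(=O)c3ccccc3)nc3cc(-c4ccccc4)nn23)cc(OC)c1OC` gives 15800 nM in this assay.
Compound 3 `COc1ccc(-c2cc(/C=C/C(=O)c3ccccc3)nc3cc(-c4ccccc4)nn23)cc1` gives 9900 nM in this assay.

Compound 2 has the highest number of the three, but the gaps are small: a 1.2-fold higher number from compound 1 to compound 2 (0.08 log units; within the scatter) and a 1.6-fold lower number from compound 2 to compound 3 (0.20 log units; within the scatter) both sit within the scatter, so none of the three can be called weaker or stronger than another. Compound 4 `COc1cc(-c2cc(/C=C/C(=O)c3ccc(Cl)cc3)nc3cc(-c4ccccc4)nn23)cc(OC)c1OC` differs from compound 2 by chloro in place of hydrogen on an aromatic carbon; the chlorine sits on the ring of the benzoyl group, para to a large group. Going by the values given here, only one measured step touches that same place, where a methoxy group gave way to hydrogen and the number stayed within the scatter: a 1.2-fold higher number from compound 1 to compound 2 (0.08 log units; within the scatter). The step to compound 3 alters a different ring and says nothing about this position. Among the compounds with values here, no measured step exchanges hydrogen for chloro, so the expectation rests on how little that position has mattered so far. A step of about a 1.3-fold lower number from compound 2 to compound 4 (0.12 log units; within the scatter) is expected, no larger than the scatter. Compound 4 is therefore estimated at 12000 nM, with a range from 5000 nM to 30000 nM.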

Compound 4, half-maximal inhibitory concentration: 32500 nM
Estimate against measurement, compound 4: 2.7-fold (0.43 log units) below, and the stated range ends below it.
By their numbers in this assay, from the lowest: compounds 3, 1 and 2 (each within the scatter of the next); then compound 4.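

In this assay chloro in place of hydrogen brings a 2.1-fold higher number from compound 2 to compound 4 (0.31 log units; beyond the scatter) and chloro in place of methoxy brings a 2.5-fold higher number from compound 1 to compound 4 (0.39 log units; beyond the scatter) on the ring of the benzoyl group, so this position is not indifferent to what it carries. Hydrogen and methoxy could not be told apart here, yet chloro gives a weaker inhibitor than either, by a modest margin just beyond the scatter. Nothing available explains why chloro stands apart from the other two groups.

The compounds shown leave open whether an amine, a carboxylic acid or a bromo group at this position would also give a weaker inhibitor. They also leave open whether chloro would have the same effect on a compound carrying 4-methoxyphenyl in place of 3,4,5-trimethoxyphenyl.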